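Replacing a Vinyl with 2-Bromophenyl beside the Sulfur Chain

The source may report more compounds than this note shows. Statements on the series, on what has been measured and on what is new or still open speak of the compounds shown alone.

Measured compounds:
Compound 1 `Cc1cc(N2CC[C@@H](C)[C@@H](N(C)c3ncnc4[nH]ccc34)C2)n2nc(SCC3CC3)nc2n1` gives 21400 nM in a functional assay on HGC-27 cells (Homo sapiens) for inhibition, read by MTT assay, with a stated time of 72 h; on this read-out lower numbers stand for stronger inhibition and higher numbers for weaker inhibition.
Compound 2 `Cc1cc(N2CC[C@@H](C)[C@@H](N(C)c3ncnc4[nH]ccc34)C2)n2nc(SCc3cc(Cl)ccc3Cl)nc2n1` gives 19200 nM.
Compound 3 `C=CCSc1nc2nc(C)cc(N3CC[C@@H](C)[C@@H](N(C)c4ncnc5[nH]ccc45)C3)n2n1` gives 35200 nM.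

Compound 3 shows the highest number of the three, yet a 1.6-fold higher number from compound 1 to compound 3 (0.22 log units; within the scatter) and a 1.8-fold higher number from compound 2 to compound 3 (0.26 log units; within the scatter) both stay within the scatter, so the three compounds cannot be ranked. Compound 4 `Cc1cc(N2CC[C@@H](C)[C@@H](N(C)c3ncnc4[nH]ccc34)C2)n2nc(SCc3ccccc3Br)nc2n1` differs from compound 3 in one place: 2-bromophenyl in place of vinyl on a saturated chain carbon bound to a sulfur. Two earlier steps touch the same carbon: a 1.1-fold lower number from compound 1 to compound 2 (0.05 log units; within the scatter) and a 1.8-fold higher number from compound 2 to compound 3 (0.26 log units; within the scatter), each within the scatter. Putting an aromatic ring on that carbon, or taking it away, has so far moved nothing beyond noise. Compound 4 is therefore expected near 22000 nM, between 10000 nM and 45000 nM, with a 1.6-fold lower number from compound 3 to compound 4 (0.20 log units; within the scatter) as the expected step.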

Compound 4, half-maximal inhibitory concentration: 21300 nM
Beside the measured number, compound 4's estimate is 1.0-fold (0.01 log units) above it; the measured number falls inside the stated range.
By their numbers in this assay, from the lowest: compounds 2, 4, 1 and 3 (each within the scatter of the next).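

The steps of a 1.7-fold lower number from compound 3 to compound 4 (0.22 log units; within the scatter) and a 1.1-fold higher number from compound 2 to compound 4 (0.05 log units; within the scatter) and a 1.0-fold lower number from compound 1 to compound 4 (0.00 log units; within the scatter) add a bromine-bearing aromatic ring to the groups compared at this saturated chain carbon bound to a sulfur. All four compounds now lie within the scatter of one another in this assay, whether the group there is vinyl, cyclopropyl, 2,5-dichlorophenyl or 2-bromophenyl. Nothing available explains this flat picture. On these data alone, whether an amine, a carboxylic acid or a longer chain on this carbon would shift the number beyond the scatter remains open.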